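The compounds below may be only part of what the source reports. "The series", "measured", "known", "first", "only" and "open" are said of these compounds alone.

In a functional assay on DU-145 cells (Homo sapiens) for antiproliferative activity, read by propidium iodide staining, with a stated time of 96 h (on this read-out lower numbers stand for stronger inhibition and higher numbers for weaker inhibition), compound 1 (`CC(O)(COc1ccc(S(F)(F)(F)(F)F)cc1)C(=O)Nc1ccc(C#N)c(C(F)(F)F)c1`) gives 25500 nM and compound 2 (`CC(O)(COc1ccc(S(F)(F)(F)(F)F)cc1)C(=O)Nc1ccc(C#N)cc1C(F)(F)F`) gives 16000 nM in this cell read-out. Within the data shown here, these two values lie within the scatter of each other, so the numbers so far do not separate compound 2 from compound 1.

Compound 3 (`CC(O)(COc1ccc(S(F)(F)(F)(F)F)cc1)C(=O)Nc1ccc([N+](=O)[O-])cc1C(F)(F)F`) departs from compound 2 in a single place, with nitro in place of cyano on an aromatic carbon of the shared core. That carbon belongs to a six-membered aromatic ring of carbon only and sits meta to a trifluoromethyl group and para to a large group.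

Among the measured compounds shown here, no measured pair shows this exchange, so the data give no direct guide to its effect in this assay and favour no direction. A shift beyond the scatter is therefore not expected. The expected step of a 1.1-fold lower number from compound 2 to compound 3 (0.03 log units; within the scatter) is an estimate that stays within the usual spread of repeated measurements. For compound 3 the estimated value is 15000 nM with an expected range from 6000 nM to 35000 nM in this test.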

Compound 3, half-maximal inhibitory concentration: 15400 nM
Beside the measured number, compound 3's estimate is 1.0-fold (0.01 log units) below it; the range from low to high includes it.
By their numbers in this assay, from the lowest: compounds 3, 2 and 1 (each within the scatter of the next).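

In this assay, among these compounds, the exchange of cyano for nitro on this aromatic carbon, meta to a trifluoromethyl group and para to a large group, comes to a 1.0-fold lower number from compound 2 to compound 3 (0.02 log units; within the scatter), giving the first direct reading of this change and leaving the two compounds unseparated. Nitro carries more heavy atoms and more hydrogen-bond acceptors than cyano, and it replaces a triple bond with a double bond, yet at this position these differences in structure go with no shift beyond the scatter. No available evidence accounts for this outcome.

Whether any group on this carbon can move the number beyond the scatter stays open, as the compounds shown carry only cyano or nitro there and include no amine, carboxylic acid, acetyl group or plain hydrogen in that place. Also open is whether nitro would match cyano with the trifluoromethyl group placed as in compound 1, as the compounds shown offer no nitro counterpart to compound 1.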